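From Ethyl to Isopropyl on the Side Chain

This account rests on a few compounds, and the source may have more. Where it says the series, first, only, none or still open, it means among the compounds named here.

In a functional assay on HUVEC cells (Homo sapiens), read by scintillation counting and thymidine incorporation, with a stated time of 24 h (on this read-out lower numbers stand for stronger inhibition and higher numbers for weaker inhibition), compound 1 `CCC(C)n1ncn(-c2ccc(N3CCN(c4ccc(OC[C@@H]5CO[C@@](CC6CCCC6)(c6ccc(Cl)cc6Cl)O5)cc4)CC3)cc2)c1=O` gives 512 nM, compound 2 `CCC(C)n1ncn(-c2ccc(N3CCN(c4ccc(OC[C@@H]5CO[C@@](CN6CCN(C)CC6)(c6ccc(Cl)cc6Cl)O5)cc4)CC3)cc2)c1=O` gives 396 nM and compound 3 `CCc1nccn1C[C@@]1(c2ccc(Cl)cc2Cl)OC[C@@H](COc2ccc(N3CCN(c4ccc(-n5cnn(C(C)CC)c5=O)cc4)CC3)cc2)O1` gives 224 nM. Compound 3 stands clearly apart from only one of the other two: the data show a 2.3-fold lower number from compound 1 to compound 3 (0.36 log units; beyond the scatter), but only a 1.8-fold lower number from compound 2 to compound 3 (0.25 log units; within the scatter).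

Compound 4 `CCC(C)n1ncn(-c2ccc(N3CCN(c4ccc(OC[C@@H]5CO[C@@](Cn6ccnc6C(C)C)(c6ccc(Cl)cc6Cl)O5)cc4)CC3)cc2)c1=O` turns the 2-ethyl-1H-imidazol-1-yl group of compound 3 into 2-isopropyl-1H-imidazol-1-yl, with methyl in place of hydrogen on a saturated chain carbon bound to an aromatic carbon and a saturated chain carbon. This places methyl in place of hydrogen on a saturated chain carbon bound to an aromatic carbon and a saturated chain carbon.

The measured steps that bear on this exchange a whole group on a saturated chain carbon bound to a saturated ring carbon, and none of them tests a single added methyl. Even a 2.3-fold lower number from compound 1 to compound 3 (0.36 log units; beyond the scatter) is only modest, while a 1.3-fold lower number from compound 1 to compound 2 (0.11 log units; within the scatter) stays within the scatter. The expected step is therefore a 1.0-fold lower number from compound 3 to compound 4 (0.01 log units; within the scatter), with no shift beyond the scatter anticipated. Compound 4 is estimated at 220 nM, with an expected range of 100 nM to 480 nM.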

Compound 4, half-maximal inhibitory concentration: 84 nM
The estimate for compound 4 lay 2.6-fold (0.42 log units) above the measured number; the whole stated range lies above it.
By their numbers in this assay, from the lowest: compound 4; then compounds 3, 2 and 1 (each within the scatter of the next, the first and the last beyond it).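

In this assay, going by these compounds alone, this is the first step that tests a single added methyl: going from ethyl to isopropyl gives a 2.7-fold lower number from compound 3 to compound 4 (0.43 log units; beyond the scatter) and shows that one extra carbon on a saturated chain carbon bound to an aromatic carbon and a saturated chain carbon can move the number clearly. The 2-isopropyl-1H-imidazol-1-yl group also stands clear of the two non-imidazole side chains, with a 4.7-fold lower number from compound 2 to compound 4 (0.67 log units; beyond the scatter) against 4-methylpiperazin-1-yl and a 6.1-fold lower number from compound 1 to compound 4 (0.78 log units; beyond the scatter) against cyclopentyl, so compound 4 has the lowest number of the four. Nothing shown gives a measured reason for the effect of this methyl.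

On these data alone, it remains open whether a tert-butyl or cyclopropyl group in place of isopropyl would lower the number further. As far as these compounds go, it is also open whether an amine or a hydroxyl on that same carbon would keep the gain.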